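Mirror-image partner of compound 2

The compounds below may be only part of what the source reports. "The series", "measured", "known", "first", "only" and "open" are said of these compounds alone.

Among the measured compounds shown here, in a functional assay on PBMC cells (Homo sapiens) for cytotoxicity (a higher number here means a weaker inhibitor, a lower number a stronger inhibitor), compound 2 (`O=c1ccn([C@@H]2S[C@H](CO)[C@H]2CO)c(=O)[nH]1`) gives 8500 nM, the only number so far. Compound 1 (`Cc1cn([C@@H]2S[C@H](CO)[C@H]2CO)c(=O)[nH]c1=O`) reads > 100000 nM, which is a limit of the assay. Compound 3 (`Nc1ncnc2c1ncn2[C@@H]1S[C@H](CO)[C@H]1CO`) reads > 100000 nM, again a limit.

Compound 4 (`O=c1ccn([C@H]2S[C@@H](CO)[C@@H]2CO)c(=O)[nH]1`) has the same atoms and bonds as compound 2: the two compounds have the same atoms and bonds and differ only in configuration as drawn: 3 of 3 stereo elements differ (all stereocentres are inverted: mirror images); a stereocentre at a saturated ring carbon is drawn R in compound 2 and S in compound 4; a stereocentre at a saturated ring carbon is drawn S in compound 2 and R in compound 4; a stereocentre at a saturated ring carbon is drawn R in compound 2 and S in compound 4. For the measured compounds named here, the one measured step, an at least 11-fold lower number from compound 1 to compound 2 (1.07 log units; beyond the scatter), is large and beyond the scatter, but it is a hydrogen in place of methyl on an aromatic carbon. It shows that compound 2 can separate from the rest of the series, yet it does not test configuration. Going by the values given here, no mirror-image pair has been measured, so the expectation is only loosely anchored. The nearest guide is the limit of > 100000 nM in this assay, at which 2 of the 3 values shown sit. A move to a higher number in this assay is therefore expected, with a wide margin. The expected step is a 4.1-fold higher number from compound 2 to compound 4 (0.61 log units; beyond the scatter). Compound 4 is estimated at 35000 nM, with an expected range of 10000 nM to 100000 nM.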

Compound 4, half-maximal inhibitory concentration: > 100000 nM
Compound 4 ended at the assay's limit (the forecaster's own chance of this, stated with the estimate: 45%); at least 2.8-fold (0.45 log units) between middle value and limit.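

Configuration now has a measured effect in this assay: inverting all three stereocentres gives an at least 11-fold higher number from compound 2 to compound 4 (1.07 log units; beyond the scatter), large and beyond the scatter, whereas the earlier step concerned only hydrogen in place of methyl on an aromatic carbon. Among the compounds shown here, this step isolates the drawn configuration as the sole change, so the reading of compound 2 depends on its configuration as well as on that hydrogen: the fact that compounds 2 and 4 differ only in the configuration as drawn. Compound 4 gives > 100000 nM, which is a limit of the assay, like most readings in the series: the limit of > 100000 nM in this assay, at which 3 of the 4 values shown sit.

As far as these compounds go, whether the mirror-image form of the core would separate in the same way with a different base attached remains open. Also open, from the compounds shown here alone, is how a carboxylic acid or a longer chain on the core of compound 2 would read in this assay.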